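A few compounds are considered here, and "the series" means these few. Any claim that something is new, unique, unknown or untested is made for them only; others in the source may bear on it.

Measured compounds:
Compound 1, `CCn1c(CNc2ccccc2)nnc1SCC(=O)Nc1ccc(C(=O)OC)cc1`: in an assay on isolated protein for inhibition of long-chain fatty acid transport protein 1 (Mus musculus) (on this read-out lower numbers stand for stronger inhibition and higher numbers for weaker inhibition), compound 1 has "not determined" (no result reported)
Compound 2, `CCn1c(CNc2ccccc2)nnc1SCc1nc2cc(Cl)ccc2o1`: in this assay compound 2 gives 2300 nM
Compound 3, `CCC(=O)c1ccc2oc(CS(=O)(=O)c3nnc(CNc4ccccc4)n3CC)nc2c1`: in this assay compound 3 gives 11900 nM

Compound 1 stands nowhere on the numbers shown: it carries no result in this assay, so its position among the others cannot be given. For the measured compounds named here, of the two compounds with numbers, compound 2 has the lower value and compound 3 the higher one, and that is all their two values show, as no step between them is worked out.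

Compound 4, `CCOC(=O)c1ccc(NC(=O)CSc2nnc(CNc3ccccc3)n2CC)cc1`, is the compound still to be measured in this assay. It differs from compound 1 in one place: methyl in place of hydrogen on a saturated chain carbon bound to an oxygen next to a carbonyl group. Going by the values given here, since compound 1 has no number, no step from compound 1 to compound 4 can be computed; with a change of this size, one methyl on a saturated chain carbon, no shift beyond the usual scatter is expected in this assay in either direction. With only compound 2 and compound 3 as reference points, compound 4 is estimated at 6000 nM, in a range from 1500 nM to 25000 nM, an expectation rather than a measurement.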

Compound 4, half-maximal inhibitory concentration: 1100 nM
Beside the measured number, compound 4's estimate is 5.5-fold (0.74 log units) above it, and the stated range ends above it.
By their numbers in this assay, from the lowest: compound 4; then compound 2; then compound 3.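

For the compounds shown here, with compound 1 at "not determined" (no result reported) and compound 4 at 1100 nM in this assay no step between the two can be read. The compounds shown leave open what methoxycarbonyl to ethoxycarbonyl does on this core. Nothing given here accounts for the value of compound 4.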